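Methylating a Phenol on Two Positional Isomers

A few compounds are considered here, and "the series" means these few. Any claim that something is new, unique, unknown or untested is made for them only; others in the source may bear on it.

Compound 1, `CC1(/C=C/c2ccccc2O)C=CC(=O)O1`, and compound 2, `CC1(/C=C/c2cccc(O)c2)C=CC(=O)O1`, are built from the same atoms joined differently; the difference between the two cores is not broken down here. In a functional assay on U-251 cells (Homo sapiens) for inhibition, read by sulforhodamine B assay, with a stated time of 48 h (a lower number here means a stronger inhibitor of growth, a higher number a weaker inhibitor of growth), compound 1 gives 70900 nM, while compound 2 gives 118000 nM, the highest of the three numbers measured, though its gap to compound 1 lies within the usual scatter. Compound 3, `COc1ccccc1/C=C/C1(C)C=CC(=O)O1`, differs from compound 1 by methyl in place of hydrogen on an oxygen on an aromatic ring. In this assay compound 3 gives 41100 nM, so that a 1.7-fold lower number from compound 1 to compound 3 (0.24 log units; within the scatter). Compound 4, `COc1cccc(/C=C/C2(C)C=CC(=O)O2)c1`, is not yet measured; it differs from compound 2 by methyl in place of hydrogen on an oxygen on an aromatic ring. The place of the change is described in the same words for both pairs, so this is the same change set on the other core. Within the data shown here, only one measured example of the change exists, and that step does not clear the scatter, so no firm direction can be read from it. For compound 4 the step expected is a 1.6-fold lower number from compound 2 to compound 4 (0.21 log units; within the scatter), an expectation that rests on a 1.7-fold lower number from compound 1 to compound 3 (0.24 log units; within the scatter) and on nothing more. On that basis compound 4 is estimated at 72000 nM in this assay, with a plausible range from 35000 nM to 150000 nM, and its measurement will show whether the pattern seen on the core of compound 1 carries over.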

Compound 4, concentration for total growth inhibition: 37600 nM
The estimate for compound 4 lay 1.9-fold (0.28 log units) above the measured number; the measured number falls inside the stated range.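

On the core of compound 2, replacing hydroxy with methoxy gives a 3.1-fold lower number from compound 2 to compound 4 (0.50 log units; beyond the scatter) in this assay, a modest step that clears the usual scatter on its own. Set beside the same change on the core of compound 1, this step cannot be told apart from the earlier one, so the two cores give no sign that the size of the change depends on the core: the same change on two cores in this assay, a 1.7-fold lower number (0.24 log units; within the scatter) from compound 1 to compound 3 and a 3.1-fold lower number (0.50 log units; beyond the scatter) from compound 2 to compound 4, 1.8-fold (0.26 log units) apart, within the scatter of two such steps This does not establish a general effect of the change, since the series offers only two pairs in a single assay, and the step on the core of compound 1 stays within the scatter and by itself shows no firm direction.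

The compounds shown leave open whether anything other than methoxy would serve in place of hydroxy on the aromatic ring, for example an ethoxy group with its longer chain, an amine or a carboxylic acid. They also leave open how the numbers would respond if the methyl group on the shared core gave way to an ethyl group or a longer chain.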